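Aminothiophene piperazines: swapping the aryl cap for a chlorophenylpropyl chain

The compounds below may be only part of what the source reports. "The series", "measured", "known", "first", "only" and "open" are said of these compounds alone.

Compound 1 `Nc1scc(CN2CCN(c3ccc(Cl)cc3Cl)CC2)c1C(=O)c1ccc(Cl)cc1`: -11%
Compound 2 `Nc1scc(CN2CCN(c3cccnc3)CC2)c1C(=O)c1ccc(Cl)cc1`: 3.4%

In a functional assay on CHO cells with adenosine receptor A1 (Homo sapiens) as the target, read by cAMP accumulation and immunoassay, with a stated time of 6 min, tested at 0.1 uM (a higher number here means a weaker effect of the compound at the concentration tested, a lower number a stronger effect), compound 2 stands highest of the two numbers, with a number 14.4 percentage points higher from compound 1 to compound 2 (beyond the scatter). Compound 3 `Nc1scc(CN2CCN(CCCc3ccc(Cl)cc3)CC2)c1C(=O)c1ccc(Cl)cc1` differs from compound 2 by 3-(4-chlorophenyl)propyl in place of pyridin-3-yl on an amine nitrogen in a ring. Among the compounds with values here, no measured step covers a change from an aromatic group to a chain on this ring nitrogen, so the only guide is the modest step from compound 1 to compound 2, and both values sit near zero. A step of a number 6.4 percentage points lower from compound 2 to compound 3 (within the scatter) is therefore expected, within the scatter. Compound 3 is estimated at -3%, between -22% and 16%.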

Compound 3, a percentage reported as activity, at one concentration (the size of the read-out at that concentration, not a potency): -3%
Beside the measured number, compound 3's estimate shows no gap at the digits printed, within the range that was stated.
By their numbers in this assay, from the lowest: compounds 1, 3 and 2 (each within the scatter of the next, the first and the last beyond it).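

In this assay, a group that carries its aromatic ring on a propyl chain can be placed on this ring nitrogen and still give a number that cannot be told apart from those of the groups with an aromatic ring bonded directly there: the steps are a number 6.4 percentage points lower from compound 2 to compound 3 (within the scatter) and a number 8 percentage points higher from compound 1 to compound 3 (within the scatter). Compound 3 therefore sits within the scatter of both compound 1 and compound 2, even though those two differ beyond it. Nothing here explains this result. From the compounds shown here alone, whether a benzyl group, a longer chain or a chain ending in a carboxylic acid would stand apart from these compounds remains open.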